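Replacing benzoyl with (furan-3-yl)carbonyl on the shared core

The compounds below may be only part of what the source reports. "The series", "measured", "known", "first", "only" and "open" are said of these compounds alone.

In an ADME assay on L6 cells (Rattus norvegicus) for cytotoxicity, read by resazurin assay, with a stated time of 70 h (a lower number here means a stronger inhibitor, a higher number a weaker inhibitor), compound 1 (`O=C(Nc1ccc(Cl)c(-c2nc3ncccc3o2)c1)c1cscn1`) gives 235000 nM and compound 2 (`O=C(Nc1ccc(Cl)c(-c2nc3ncccc3o2)c1)c1ccccc1`) gives 51000 nM as the lower of the two numbers. Compound 3 (`O=C(Nc1ccc(Cl)c(-c2nc3ncccc3o2)c1)c1ccoc1`) differs from compound 2 by furan-3-yl in place of phenyl on a carbonyl carbon in one place, with furan-3-yl in place of phenyl on a carbonyl carbon. For the measured compounds named here, the single measured step bearing on this is a 4.6-fold lower number from compound 1 to compound 2 (0.66 log units; beyond the scatter) and it brought phenyl in place of 1,3-thiazol-4-yl on a carbonyl carbon. With phenyl gone again, a modest move to a higher number is expected, of similar or smaller size, and a 2.2-fold higher number from compound 2 to compound 3 (0.33 log units; beyond the scatter) is the estimated step. For compound 3 the expected value is 110000 nM (estimated range 45000 nM to 260000 nM).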

Compound 3, half-maximal inhibitory concentration: 65000 nM
Compound 3: middle estimate off by 1.7-fold (0.23 log units), on the high side; low and high end bracket the measured number.
By their numbers in this assay, from the lowest: compounds 2 and 3 (each within the scatter of the next); then compound 1.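

In this assay the exchange of phenyl for furan-3-yl gives a 1.3-fold higher number from compound 2 to compound 3 (0.11 log units; within the scatter), so on this carbonyl carbon a five-membered aromatic ring with one hetero atom reads the same as the six-membered carbon ring. Compound 1 stays apart, with a 3.6-fold lower number from compound 1 to compound 3 (0.56 log units; beyond the scatter), so a five-membered aromatic ring alone does not go with the higher number of compound 1. Nothing shown here accounts for the gap between 1,3-thiazol-4-yl and furan-3-yl. Still open, from the compounds shown here alone, is how a pyridin-3-yl ring would read at this position, and how a phenyl ring carrying an amine or a carboxylic acid would read.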